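Phenyl in place of phenoxy: compound 3 to compound 4

A few compounds are considered here, and "the series" means these few. Any claim that something is new, unique, unknown or untested is made for them only; others in the source may bear on it.

- Compound 1 `O=C(CCCCc1cn(Cc2ccc(Br)cc2)nn1)NO`: 7910 nM
- Compound 2 `CC(C)(C)c1ccc(Cn2cc(CCCCC(=O)NO)nn2)cc1`: 7200 nM
- Compound 3 `O=C(CCCCc1cn(Cc2ccc(Oc3ccccc3)cc2)nn1)NO`: 4490 nM

These three compounds were tested in a functional assay on DU-145 cells (Homo sapiens) for inhibition, read by MTT assay; a higher number here means a weaker inhibitor of growth, a lower number a stronger inhibitor of growth. Compound 3 stands within the scatter of both others, as a 1.8-fold lower number from compound 1 to compound 3 (0.25 log units; within the scatter) and a 1.6-fold lower number from compound 2 to compound 3 (0.21 log units; within the scatter) show. Compound 4 `O=C(CCCCc1cn(Cc2ccc(-c3ccccc3)cc2)nn1)NO` keeps the shared core but has phenyl in place of phenoxy on an aromatic carbon. For the measured compounds named here, no measured compound carries this phenyl, so the nearest guide is the other changes at that place. Besides the two steps above, there is a 1.1-fold lower number from compound 1 to compound 2 (0.04 log units; within the scatter), and none goes beyond the scatter. No step beyond the scatter is therefore expected here. The expected step is a 1.1-fold higher number from compound 3 to compound 4 (0.05 log units; within the scatter). For compound 4, the estimated value is 5000 nM, with an expected range of 2500 nM to 9500 nM.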

Compound 4, concentration for 50% growth inhibition: 1210 nM
The estimate for compound 4 lay 4.1-fold (0.62 log units) above the measured number; measured number outside the range, below it.
By their numbers in this assay, from the lowest: compound 4; then compounds 3, 2 and 1 (each within the scatter of the next).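

Swaps among bromo, tert-butyl and phenoxy at this position stayed within the scatter in this assay and phenyl is the first group to stand apart, with a 3.7-fold lower number from compound 3 to compound 4 (0.57 log units; beyond the scatter) and a 6.0-fold lower number from compound 2 to compound 4 (0.77 log units; beyond the scatter) and also a 6.5-fold lower number from compound 1 to compound 4 (0.82 log units; beyond the scatter) at this aromatic carbon. Removing the oxygen of phenoxy, the only atom that differs between the two groups, is enough to give a step beyond the scatter. Nothing available explains this gain.

As far as these compounds go, whether benzyl, or a phenyl carrying an amine, would keep this lower number stays open.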